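The source may report more compounds than this note shows. Statements on the series, on what has been measured and on what is new or still open speak of the compounds shown alone.

Measured compounds in an in vitro assay on Sf-9 cells for inhibition of protein kinase C delta type (Homo sapiens); a higher number here means a weaker inhibitor, a lower number a stronger inhibitor:
compound 1 `CC(C)OC(=O)c1cccc(O)c1C(=O)c1c(O)cc(C(=O)O[C@@H]2CCC[C@H]2NC(=O)c2ccc(O)cc2)cc1O` gives 50 nM;
compound 2 `CCCCOC(=O)c1cccc(O)c1C(=O)c1c(O)cc(C(=O)O[C@@H]2CNC[C@H]2NC(=O)c2ccc(O)cc2)cc1O` gives 80 nM;
compound 3 `O=C(N[C@@H]1CNC[C@H]1OC(=O)c1cc(O)c(C(=O)c2c(O)cccc2C(=O)OCC2CCCCC2)c(O)c1)c1ccc(O)cc1` gives 310 nM.

Among these three numbers compound 3 stands highest, that is as the weakest inhibitor of the set. For the measured compounds named here, its nearest neighbour is compound 2, which differs from it at only one place, and the step of a 3.9-fold higher number from compound 2 to compound 3 (0.59 log units; beyond the scatter) is beyond the scatter; compound 1 lies further away still, although no single-point step connects it to compound 3.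

Compound 4 `CC(=O)OCOC(=O)c1cccc(O)c1C(=O)c1c(O)cc(C(=O)O[C@@H]2CNC[C@H]2NC(=O)c2ccc(O)cc2)cc1O` is not yet measured. It differs from compound 3 in this way: acetoxy in place of cyclohexyl on a saturated chain carbon bound to an oxygen next to a carbonyl group. Going by the values given here, the one measured step that bears on this place is a 3.9-fold higher number from compound 2 to compound 3 (0.59 log units; beyond the scatter), where the bulkier cyclohexyl on that carbon went with a modestly higher number than propyl. Acetoxy is the smaller of the two groups now exchanged, so a return in the other direction is expected, of about the size seen in that step, and not a larger one, since no measurement at this position goes beyond that range. Compound 4 is therefore expected to give 110 nM, within 40 nM to 300 nM, which means an estimated step of a 2.8-fold lower number from compound 3 to compound 4 (0.45 log units; beyond the scatter).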

Compound 4, half-maximal inhibitory concentration: 24 nM
Compound 4: middle estimate off by 4.6-fold (0.66 log units), on the high side; the measured number lies below the stated range.
By their numbers in this assay, from the lowest: compound 4; then compounds 1 and 2 (each within the scatter of the next); then compound 3.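

In this assay, the step of a 13-fold lower number from compound 3 to compound 4 (1.11 log units; beyond the scatter) shows that this saturated chain carbon bound to an oxygen next to a carbonyl group can carry a change much larger than the one seen earlier between propyl and cyclohexyl. For the compounds shown here, the step of a 3.3-fold lower number from compound 2 to compound 4 (0.52 log units; beyond the scatter) adds something the earlier compounds could not show: the number can also fall relative to propyl, so changes at this place move it in both directions, with propyl lying between cyclohexyl and acetoxy. Nothing available explains why acetoxy goes with the lowest number of these three groups.

The compounds shown leave open whether the carbonyl of acetoxy matters or its oxygens alone would do, which a methoxy group at this place could test. They also leave open whether a longer acyloxy chain, such as butanoyloxy, or a carboxylic acid would follow acetoxy.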